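Swapping the Aryl Group on the Amide: Compound 2 to Compound 3

This account rests on a few compounds, and the source may have more. Where it says the series, first, only, none or still open, it means among the compounds named here.

Measured so far:
Compound 1 `COc1ccc2c(=O)c(/C=C/C(=O)Nc3cccc(Cl)c3)coc2c1`: 1100000 nM
Compound 2 `COc1ccc2c(=O)c(/C=C/C(=O)Nc3ccccc3OC)coc2c1`: 1050000 nM

In an ADME assay on HepG2 2.2.15 cells (Homo sapiens) for cytotoxicity, read by MTT assay, with stated times of 48 h and 9 days (a higher number here means that more compound is tolerated, a lower number that less compound is tolerated), compound 1 gives 1100000 nM and compound 2 gives 1050000 nM. For the measured compounds named here, the only step between them, a 1.0-fold lower number from compound 1 to compound 2 (0.02 log units; within the scatter), changes the group on the amide-type nitrogen, and compound 2 is therefore not separated from compound 1 by more than the usual scatter of this assay.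

Compound 3 `COc1ccc2c(=O)c(/C=C/C(=O)Nc3ccc(C)cc3)coc2c1` is not yet measured. It differs from compound 2 in one place: 4-methylphenyl in place of 2-methoxyphenyl on an amide-type nitrogen. Going by the values given here, the one step that bears on this, from compound 1 to compound 2, also replaced the ring on that nitrogen and stayed within the scatter. Because a 1.0-fold lower number from compound 1 to compound 2 (0.02 log units; within the scatter) gave no real movement, compound 3 is expected to show a step of no change at the digits printed from compound 2 to compound 3 (within the scatter), none beyond the scatter. The estimate for compound 3 in this assay is 1050000 nM, with a range from 500000 nM to 2200000 nM.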

Compound 3, half-maximal cytotoxic concentration: 979000 nM
The estimate for compound 3 lay 1.1-fold (0.03 log units) above the measured number; the range from low to high includes it.
By their numbers in this assay, from the lowest: compounds 3, 2 and 1 (each within the scatter of the next).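

In this assay the 4-methylphenyl group gives a 1.1-fold lower number from compound 2 to compound 3 (0.03 log units; within the scatter) and, set against the 3-chlorophenyl group, a 1.1-fold lower number from compound 1 to compound 3 (0.05 log units; within the scatter). Compound 3 thus adds a third aryl group on the amide-type nitrogen without separating from the other two, and the 4-methylphenyl group carries 0 hydrogen-bond acceptors where the 2-methoxyphenyl group carries 1. Across these three compounds, neither that difference in acceptor count nor the choice among these three phenyl groups shows up beyond the scatter, and nothing measured here offers an explanation for this.

All three compounds carry a substituted phenyl ring on that nitrogen, so they leave open whether the same holds for a phenyl ring bearing an amine or a carboxylic acid. They also leave open what happens when a longer alkyl chain takes the place of the ring.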